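The source may hold more compounds than are shown below. What is called first, only, known or untested is meant among the compounds shown, and "the series" means these compounds.

Three compounds have been measured in an ADME assay on RAW264.7 cells (Mus musculus) for cytotoxicity, read by MTT assay, with a stated time of 24 h; a lower number here means that less compound is tolerated, a higher number that more compound is tolerated:

Compound 1, `O=C(Nc1ccc(F)cc1F)c1cc(F)ccc1O`: 15700 nM
Compound 2, `O=c1oc2ccc(I)cc2c(=O)n1-c1ccc(Cl)cc1F`: 8900 nM
Compound 3, `O=C(Nc1ccc(F)cc1F)c1cc(Cl)ccc1O`: 14600 nM

Compound 3 and compound 1 share a core and differ by fluoro in place of chloro on an aromatic carbon. In this assay this gives a 1.1-fold higher number from compound 3 to compound 1 (0.03 log units; within the scatter), so the two values are within the scatter of each other and no direction can be read from them. Compound 2 rests on a different core; how the two cores differ is not broken down here. Its value is within the scatter of compound 3 and of compound 1.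

Compound 4, `O=c1oc2ccc(I)cc2c(=O)n1-c1ccc(F)cc1F`, is not yet measured. It differs from compound 2 by fluoro in place of chloro on an aromatic carbon. This is the same kind of change as that from compound 3 to compound 1, but its surroundings differ: here the place is meta to a fluoro group and para to a large group, whereas in compound 3 it is meta to a large group and para to a hydroxy group. Going by the values given here, because a 1.1-fold higher number from compound 3 to compound 1 (0.03 log units; within the scatter) was within the scatter, compound 4 is expected to show a 1.1-fold higher number from compound 2 to compound 4 (0.03 log units; within the scatter) in this assay, an estimate that rests on the one comparable pair only. Compound 4 is therefore estimated at 9500 nM, between 5000 nM and 18000 nM.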

Compound 4, half-maximal cytotoxic concentration: 15700 nM
The estimate for compound 4 lay 1.7-fold (0.22 log units) below the measured number, within the range that was stated.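

In this assay, fluoro in place of chloro on an aromatic carbon gives a 1.8-fold higher number from compound 2 to compound 4 (0.25 log units; within the scatter), so this step shows no direction. Set beside the earlier case, the same change on the two cores does not give steps that can be told apart: the same change on two cores in this assay, a 1.1-fold higher number (0.03 log units; within the scatter) from compound 3 to compound 1 and a 1.8-fold higher number (0.25 log units; within the scatter) from compound 2 to compound 4, 1.6-fold (0.21 log units) apart, within the scatter of two such steps. This shows that, across these two pairs, the change has left no readable mark on the number and that the two cores show no sign of responding to it differently, but it does not show that the change has no effect at all or that the same would hold on a further core, and the finding rests on these two pairs alone.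

The compounds shown leave open how the number would respond to an amine, a carboxylic acid or a methoxy group in place of the chloro. They also leave open whether a longer chain at that place would give a step beyond the scatter.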